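A few compounds are considered here, and "the series" means these few. Any claim that something is new, unique, unknown or untested is made for them only; others in the source may bear on it.

Compound 1 `NC(=O)c1cc(Cl)c2c(Cl)c(C#CC3CCOCC3)n([C@H]3CCCNC3)c2n1`: 69 nM in a functional assay on KG-1 cells (Homo sapiens) for antiproliferative activity; a higher number here means that more compound is needed for the effect, a lower number that less compound is needed
Compound 2 `CC(C)(C#N)CC#Cc1c(Cl)c2c(Cl)cc(C(N)=O)nc2n1[C@H]1CCCNC1`: 113 nM in this assay

Among the two measured compounds, compound 2 gives the highest number, and its nearest neighbour is compound 1, whose value sits within the scatter of it. Compound 3 `CC(O)CC#Cc1c(Cl)c2c(Cl)cc(C(N)=O)nc2n1[C@H]1CCCNC1` carries 1-hydroxyethyl in place of 1-cyano-1-methylethyl on a saturated chain carbon bound to a triple-bonded carbon. Going by the values given here, the only step that touches this part of the molecule is a 1.6-fold higher number from compound 1 to compound 2 (0.21 log units; within the scatter), which stayed within the scatter, so no step beyond the scatter is expected here either. Compound 3 is therefore expected to give 100 nM in this assay, estimated between 40 nM and 250 nM, which would mean a step of a 1.1-fold lower number from compound 2 to compound 3 (0.05 log units; within the scatter).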

Compound 3, half-maximal effective concentration: 48 nM
Compound 3: middle estimate off by 2.1-fold (0.32 log units), on the high side; the measured number falls inside the stated range.
By their numbers in this assay, from the lowest: compounds 3, 1 and 2 (each within the scatter of the next, the first and the last beyond it).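

In this assay, 2-hydroxypropyl in place of 2-cyano-2-methylpropyl gives a 2.4-fold lower number from compound 2 to compound 3 (0.37 log units; beyond the scatter), a modest change but, unlike the step between the two earlier compounds, one beyond the scatter. The same group in place of oxan-4-yl gives a 1.4-fold lower number from compound 1 to compound 3 (0.16 log units; within the scatter), which stays within the scatter, so this position has so far separated only compound 2 and compound 3. Nothing available explains this difference.

Still open, from the compounds shown here alone, is whether an amine or a carboxylic acid in place of the hydroxyl, or a longer chain carrying the hydroxyl, would shift the number further.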